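This account rests on a few compounds, and the source may have more. Where it says the series, first, only, none or still open, it means among the compounds named here.

Measured compounds in the series:

compound 1, `C/C(=N\NC(=S)Nc1ccc(I)cc1)c1ccccn1`: 6.61 nM
compound 2, `C/C(=N\NC(=S)Nc1cccc(I)c1)c1ccccn1`: 45 nM
compound 3, `C/C(=N\NC(=S)Nc1ccc([N+](=O)[O-])cc1)c1ccccn1`: 52 nM

All three were run in a functional assay on MCF7 cells (Homo sapiens) for cytotoxicity, read by MTT assay, with a stated time of 48 h; on this read-out lower numbers stand for stronger inhibition and higher numbers for weaker inhibition. Compound 1 gives 6.61 nM, compound 2 gives 45 nM, and compound 3 gives 52 nM. The values of compound 2 and compound 3 sit within the scatter of each other, so no order between them can be read. Compound 1 stands apart from both.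

Compound 1 and compound 2 share the same atoms joined differently; the difference between the two cores is not broken down here.

The change nitro in place of iodo on an aromatic carbon has been measured once: a 7.9-fold higher number from compound 1 to compound 3 (0.90 log units; beyond the scatter). In compound 4, `C/C(=N\NC(=S)Nc1cccc([N+](=O)[O-])c1)c1ccccn1`, not yet measured in this assay, the same kind of change is made on compound 2: nitro in place of iodo on an aromatic carbon. The two changes are of the same kind but not the same, since the place differs, one "para to a large group" and the other "meta to a large group".

Two points support the expectation for compound 4: the step from compound 1 to compound 3, and the closeness of compound 2 to compound 3. Because compound 2 already gives 45 nM, a step of the full size seen in a 7.9-fold higher number from compound 1 to compound 3 (0.90 log units; beyond the scatter) is not assumed; a smaller loss is expected, a 3.3-fold higher number from compound 2 to compound 4 (0.52 log units; beyond the scatter). Compound 4 is therefore estimated at 150 nM, with a likely range from 50 nM to 500 nM.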

Compound 4, half-maximal inhibitory concentration: 38 nM
For compound 4 the middle estimate is 3.9-fold (0.60 log units) above the measured one, and the stated range ends above it.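

In this assay, nitro in place of iodo on an aromatic carbon, meta to a large group, gives a 1.2-fold lower number from compound 2 to compound 4 (0.07 log units; within the scatter), so no effect of the change can be read on this core. The loss seen when the same change is made para to a large group therefore does not carry over to the other place, and the two steps differ clearly: the same change on two cores in this assay, a 7.9-fold higher number (0.90 log units; beyond the scatter) from compound 1 to compound 3 and a 1.2-fold lower number (0.07 log units; within the scatter) from compound 2 to compound 4, 9.3-fold (0.97 log units) apart, beyond the scatter of two such steps

This shows that, within these four compounds, the size of the step from iodo to nitro cannot be transferred from one core to the other; it does not show why, and with a single pair for each place it sets no general rule for either place.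

Open, from the compounds shown here alone, is whether an amine or a carboxylic acid in place of iodo would give steps that also differ between the two places, or whether the gap belongs to the pair of iodo and nitro alone. Also open, going by these compounds, is whether the same gap between the two steps would appear on a cell line other than the one in this assay.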